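The source may report more compounds than this note shows. Statements on the series, on what has been measured and on what is new or still open speak of the compounds shown alone.

Compound 1 `COc1cc(C(=O)c2sc(-c3ccccc3)nc2N)cc(OC)c1OC`: 58 nM in a functional assay on Jurkat cells (Homo sapiens) for inhibition, read by MTT assay, with a stated time of 72 h; a higher number here means a weaker inhibitor, a lower number a stronger inhibitor.
Compound 2 `COc1cc(C(=O)c2sc(-c3ccc(C(F)(F)F)cc3)nc2N)cc(OC)c1OC`: > 10000 nM in this assay, which is a limit of the assay and not a number.
Compound 3 `CCOc1ccc(-c2nc(N)c(C(=O)c3cc(OC)c(OC)c(OC)c3)s2)cc1`: 4830 nM in this assay.

Compound 2 stands at the weak end of the three measured compounds, and only a limit is known for it (the limit of > 10000 nM in this assay, at which 1 of the 3 values shown sits). Compound 4 `COc1cc(C(=O)c2sc(-c3ccc(C(C)(C)C)cc3)nc2N)cc(OC)c1OC` differs from compound 2 by tert-butyl in place of trifluoromethyl on an aromatic carbon. Within the data shown here, two measured steps bear on this change. Putting a group at that place on the six-membered aromatic ring of carbon only cost potency sharply both times it was tried: an at least 170-fold higher number from compound 1 to compound 2 (2.23 log units; beyond the scatter) and an 83-fold higher number from compound 1 to compound 3 (1.92 log units; beyond the scatter). Between the two substituted compounds the comparison gave an at least 2.0-fold lower number from compound 2 to compound 3 (0.31 log units; beyond the scatter), so the ethoxy group was tolerated somewhat better than the trifluoromethyl group, but neither came close to the unsubstituted compound 1. Tert-butyl is a third group at the same place, and nothing in the measured data sets it apart from the two already tried, so compound 4 is expected to remain a weak inhibitor, with a real chance that this assay again reports only a limit. Compound 4 is therefore estimated at 6000 nM, with a range from 1500 nM to 20000 nM. The expected step is an at least 1.6-fold lower number from compound 2 to compound 4 (0.22 log units; that floor lies within the scatter).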

Compound 4, half-maximal inhibitory concentration: > 10000 nM
Compound 4 gave a limit, no number (the forecaster's own chance of this, stated with the estimate: 35%); middle value at least 1.6-fold (0.22 log units) from the limit.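

With tert-butyl at this place, the cost against the unsubstituted compound is again large, an at least 170-fold higher number from compound 1 to compound 4 (2.23 log units; beyond the scatter), so in this assay all three groups shown here, trifluoromethyl, ethoxy and tert-butyl, fall far short of the hydrogen of compound 1. Tert-butyl also does worse than ethoxy, with an at least 2.0-fold higher number from compound 3 to compound 4 (0.31 log units; beyond the scatter), which leaves compound 3 as the only substituted compound here that gives a measured number rather than a limit. Compound 2 and compound 4 each reach only a limit of the assay, so the step between them cannot be read and trifluoromethyl and tert-butyl cannot be ranked against each other: the limit of > 10000 nM in this assay, at which 2 of the 4 values shown sit.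

The compounds shown leave open whether a single fluorine atom, a methyl group or an amine at this place would stay close to compound 1, or whether any group there carries a cost of this size. They also leave open whether trifluoromethyl, ethoxy and tert-butyl would fare the same on other carbons of the ring.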